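The source may hold more compounds than are shown below. What is called first, only, known or untested is meant among the compounds shown, and "the series" means these compounds.

Measured so far:
Compound 1 `COc1cc2nc(N3CCN(C(=O)c4ccccc4C(F)(F)F)CC3)nc(N)c2cc1OC` gives 6.43 in a functional assay for antagonist activity at Alpha-1A adrenergic receptor (Rattus norvegicus); on this read-out lower numbers stand for lower potency and higher numbers for higher potency (the scale is a negative logarithm).
Compound 2 `COc1cc2nc(N3CCN(C(=O)c4cccc(C(F)(F)F)c4)CC3)nc(N)c2cc1OC` gives 7.49 in this assay.

Going by the values given here, compound 2 stands at the top of these two numbers; the only neighbour is compound 1, which lies a number 1.06 log units higher from compound 1 to compound 2 (beyond the scatter). That single step, from the 2-(trifluoromethyl)phenyl group of compound 1 to the 3-(trifluoromethyl)phenyl group of compound 2, is large and well beyond the scatter, and it shows that where the trifluoromethyl group sits on the ring attached to the carbonyl carbon matters a great deal here.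

Compound 3 `COc1cc2nc(N3CCN(C(=O)c4ccc(C(F)(F)F)cc4)CC3)nc(N)c2cc1OC` has not yet been measured. Its difference from compound 2 is 4-(trifluoromethyl)phenyl in place of 3-(trifluoromethyl)phenyl on a carbonyl carbon. Among the compounds with values here, this is a second move of the same group around the same ring, so the one measured step is the only guide, and it says little about whether the next move helps or hurts. The expectation is that compound 3 keeps a potency near that of compound 2, with a step of a number 0.29 log units lower from compound 2 to compound 3 (within the scatter) and wide room on either side. Compound 3 is estimated at 7.2, ranging from 6.5 to 7.9.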

Compound 3, negative logarithm of the antagonist equilibrium constant: 7.43
Estimate against measurement, compound 3: 0.23 log units below; low and high end bracket the measured number.
By their numbers in this assay, from the lowest: compound 1; then compounds 3 and 2 (each within the scatter of the next).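

In this assay, exchanging the 3-(trifluoromethyl)phenyl group for the 4-(trifluoromethyl)phenyl group gives a number 0.06 log units lower from compound 2 to compound 3 (within the scatter), so this change of attachment point on the ring leaves no difference that can be told apart from ordinary assay noise. The 4-(trifluoromethyl)phenyl group also stands clear of the 2-(trifluoromethyl)phenyl group, with a number 1.00 log units higher from compound 1 to compound 3 (beyond the scatter), which shows that the earlier gap was not special to compound 2: among these three isomers, compound 1 alone stands apart, while compound 2 and compound 3 sit together. Nothing given here explains why the 2-(trifluoromethyl)phenyl group stands apart.

The compounds shown leave open whether a plain phenyl group, carrying no trifluoromethyl group at all, would sit with compound 1 or with compound 2 and compound 3, and so whether the trifluoromethyl group adds to the number or the 2-(trifluoromethyl)phenyl group takes away from it. They also leave open whether the same pattern across the three isomers would hold for another group on this ring, such as a chlorine atom, a methoxy group or a nitrile.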